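The compounds below may be only part of what the source reports. "The series", "measured", "known", "first", "only" and "open" are said of these compounds alone.

Measured in an ADME assay on microsomes from liver (Homo sapiens) for metabolic stability; on this read-out lower numbers stand for a shorter-lived compound and higher numbers for a longer-lived compound:
compound 1 `CC(C)C(c1ccc(-c2ccc3cccc(F)c3c2)[nH]c1=O)N1CCCCS1(=O)=O` gives 0.373 h.
compound 2 `CC(C)C(/C=C1/CCNC1=O)c1ccc(-c2ccc3cccc(F)c3c2)[nH]c1=O` gives 0.987 h.
compound 3 `CC(C)C(CC(N)=O)c1ccc(-c2ccc3cccc(F)c3c2)[nH]c1=O` gives only a limit of the assay, < 0.0667 h (the limit of < 0.0667 h in this assay, at which 1 of the 3 values shown sits).

Compound 1 holds the lower of the two numbers in this assay; its nearest neighbour is compound 2, with a 2.6-fold higher number from compound 1 to compound 2 (0.42 log units; beyond the scatter). Compound 4 `Cc1c[nH]c(C(c2ccc(-c3ccc4cccc(F)c4c3)[nH]c2=O)C(C)C)n1` differs from compound 1 at the one place that varies across the measured set: a group of 6 heavy atoms (4 carbon, 2 nitrogen; one five-membered aromatic ring with 2 hetero atoms) in place of a group of 8 heavy atoms (4 carbon, 1 nitrogen, 2 oxygen, 1 sulfur; one six-membered non-aromatic ring with 2 hetero atoms), on a saturated chain carbon bound to an aromatic carbon and a saturated chain carbon. Both measured steps from compound 1 bear on it: the modest rise already noted to compound 2, and an at least 5.5-fold lower number from compound 1 to compound 3 (0.74 log units; beyond the scatter). Exchanges at this carbon thus move the half-life in either direction; none of the measured steps introduces an aromatic ring here, so the direction for compound 4 is undecided and a modest step, either way, is expected. Compound 4 is estimated at 0.4 h, between 0.12 h and 1.3 h. The expected step is a 1.1-fold higher number from compound 1 to compound 4 (0.03 log units; within the scatter).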

Compound 4, half-life: 0.09 h
For compound 4 the middle estimate is 4.4-fold (0.65 log units) above the measured one; measured number below the stated range.
By their numbers in this assay, from the lowest: compound 4; then compound 1; then compound 2. At a limit, below all of these: compound 3.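

Within the data shown here, at this saturated chain carbon an aromatic ring enters for the first time, and in this assay 4-methyl-1H-imidazol-2-yl gives a 4.1-fold lower number from compound 1 to compound 4 (0.62 log units; beyond the scatter), an 11-fold lower number from compound 2 to compound 4 (1.04 log units; beyond the scatter) and an at least 1.3-fold higher number from compound 3 to compound 4 (0.13 log units; that floor lies within the scatter). Of the three ring-bearing groups at this carbon, the aromatic one thus gives the shortest half-life. Compound 3 gives only a limit of the assay, so the last of these steps is only a floor: the limit of < 0.0667 h in this assay, at which 1 of the 4 values shown sits.

From the compounds shown here alone, whether the shorter half-life follows the ring or its methyl stays open. An unsubstituted imidazole, a pyridine or an oxazole at this carbon would help separate the two.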